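The compounds below may be only part of what the source reports. "The series", "measured", "known", "first", "only" and "open" are said of these compounds alone.

Series notes. Compound 1 `CCCCc1cn(C[C@H](O)[C@H]2OC(=O)C(OCc3ccccc3)=C2OCc2ccccc2)nn1` gives 32800 nM in a functional assay on HepG2 cells (Homo sapiens) for antiproliferative activity, read by MTT assay, with a stated time of 72 h; on this read-out lower numbers stand for stronger inhibition and higher numbers for weaker inhibition. Compound 2 `CCCCCCCCCCc1cn(C[C@H](O)[C@H]2OC(=O)C(OCc3ccccc3)=C2OCc2ccccc2)nn1` gives 12200 nM in this assay, and compound 3 `O=C1O[C@H]([C@@H](O)Cn2cc(-c3cc(F)cc(F)c3)nn2)C(OCc2ccccc2)=C1OCc1ccccc1` gives 11600 nM. Compound 3 is set apart from compound 1 only: a 2.8-fold lower number from compound 1 to compound 3 (0.45 log units; beyond the scatter), whereas a 1.1-fold lower number from compound 2 to compound 3 (0.02 log units; within the scatter). Compound 4 `COc1ccc(-c2cn(C[C@H](O)[C@H]3OC(=O)C(OCc4ccccc4)=C3OCc3ccccc3)nn2)cc1` carries 4-methoxyphenyl in place of 3,5-difluorophenyl on an aromatic carbon. Going by the values given here, no measured step swaps one aryl group for another at that carbon; the steps that touch it, a 2.8-fold lower number from compound 1 to compound 3 (0.45 log units; beyond the scatter) and a 1.1-fold lower number from compound 2 to compound 3 (0.02 log units; within the scatter), replace a chain with the difluorophenyl and are modest at most. On that basis a step of about a 1.0-fold higher number from compound 3 to compound 4 (0.01 log units; within the scatter) is expected, with no direction beyond the scatter. Compound 4 is estimated at 12000 nM in this assay, within a range from 4000 nM to 36000 nM.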

Compound 4, half-maximal inhibitory concentration: 46400 nM
Compound 4: middle estimate off by 3.9-fold (0.59 log units), on the low side; the whole stated range lies below it.
By their numbers in this assay, from the lowest: compounds 3 and 2 (each within the scatter of the next); then compounds 1 and 4 (each within the scatter of the next).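

In this assay, the choice of aryl group on this aromatic carbon of the five-membered ring matters, which the chain-to-aryl steps could not show: a 4.0-fold higher number from compound 3 to compound 4 (0.60 log units; beyond the scatter) for 4-methoxyphenyl in place of 3,5-difluorophenyl. An aryl group alone does not secure the lower numbers: a 3.8-fold higher number from compound 2 to compound 4 (0.58 log units; beyond the scatter), and a 1.4-fold higher number from compound 1 to compound 4 (0.15 log units; within the scatter) leaves 4-methoxyphenyl level with butyl. Nothing at hand explains this difference between the two aryl groups.

The swap changes the fluorines and the methoxy together, so the two remain unseparated. Going by these compounds, whether unsubstituted phenyl at this carbon would sit nearer compound 3 or compound 4 stays open.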